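Compound 3 and the dichlorophenyl swap

A few compounds are considered here, and "the series" means these few. Any claim that something is new, unique, unknown or untested is made for them only; others in the source may bear on it.

compound 1 `Cc1cccc(C(=O)N(C(=S)OCCN2C(=O)c3ccccc3C2=O)c2ccc(Cl)cc2)c1`: 58000 nM
compound 2 `O=C1c2ccccc2C(=O)N1CCOC(=S)N(C(=O)c1cccc([N+](=O)[O-])c1)c1ccc(Cl)cc1`: 18000 nM
compound 3 `O=C1c2ccccc2C(=O)N1CCOC(=S)N(C(=O)c1ccc(F)cc1F)c1ccc(Cl)cc1`: 52000 nM

These numbers come from an ADME assay on MT4 cells (Homo sapiens) for cytotoxicity, read by MTT assay; a lower number here means that less compound is tolerated, a higher number that more compound is tolerated. Compound 3, at 52000 nM, lies close to compound 1 and well clear of compound 2. Compound 4 `O=C1c2ccccc2C(=O)N1CCOC(=S)N(C(=O)c1cccc(Cl)c1Cl)c1ccc(Cl)cc1` is not yet measured. It carries 2,3-dichlorophenyl in place of 2,4-difluorophenyl on a carbonyl carbon.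

Three measured steps change the group at this place. The first, a 1.1-fold lower number from compound 1 to compound 3 (0.05 log units; within the scatter), stays within the scatter. The other two involve the nitro compound and are modest: a 3.2-fold lower number from compound 1 to compound 2 (0.51 log units; beyond the scatter) and a 2.9-fold higher number from compound 2 to compound 3 (0.46 log units; beyond the scatter). With no nitro group entering, no step beyond the scatter is expected. The expected step is a 1.2-fold lower number from compound 3 to compound 4 (0.09 log units; within the scatter). For compound 4 the estimated value is 42000 nM, with an expected range of 18000 nM to 90000 nM.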

Compound 4, half-maximal cytotoxic concentration: 54000 nM
Estimate against measurement, compound 4: 1.3-fold (0.11 log units) below; the measured number falls inside the stated range.
By their numbers in this assay, from the lowest: compound 2; then compounds 3, 4 and 1 (each within the scatter of the next).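

In this assay, 2,3-dichlorophenyl on this carbonyl carbon gives a reading that cannot be told apart from that of 2,4-difluorophenyl (a 1.0-fold higher number from compound 3 to compound 4 (0.02 log units; within the scatter)) or 3-methylphenyl (a 1.1-fold lower number from compound 1 to compound 4 (0.03 log units; within the scatter)). Among these groups only 3-nitrophenyl stands apart, and this now holds against a third partner (a 3.0-fold higher number from compound 2 to compound 4 (0.48 log units; beyond the scatter)). Nothing available here explains the pattern.

The compounds shown leave open whether an amine or a carboxylic acid on this phenyl ring would shift the number as the nitro group does. They also leave open whether a larger bicyclic naphthyl group would be read the same way.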